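Replacing the piperazine aryl group: from compound 2 to compound 3

This account rests on a few compounds, and the source may have more. Where it says the series, first, only, none or still open, it means among the compounds named here.

Compound 2 `Nc1scc(CN2CCN(c3c(F)cc(F)cc3F)CC2)c1C(=O)c1ccc(Cl)cc1` stands lowest of the two numbers in a functional assay on CHO cells with adenosine receptor A1 (Homo sapiens) as the target, read by cAMP accumulation and immunoassay, with a stated time of 6 min, tested at 1 uM (on this read-out higher numbers stand for a weaker effect at the one concentration tested and lower numbers for a stronger effect), giving -56%, while compound 1 `COc1ccc(N2CCN(Cc3csc(N)c3C(=O)c3ccc(Cl)cc3)CC2)cc1` gives -15% in this assay. Among the compounds with values here, the one measured step at this position, a number 41 percentage points lower from compound 1 to compound 2 (beyond the scatter), shows that the aryl group on the ring nitrogen can move the read-out a long way. Compound 3 `Nc1scc(CN2CCN(c3cccc(Cl)c3)CC2)c1C(=O)c1ccc(Cl)cc1` differs from compound 2 as follows: 3-chlorophenyl in place of 2,4,6-trifluorophenyl on an amine nitrogen in a ring. Within the data shown here, no measured step covers 3-chlorophenyl, so the direction is uncertain; the step from compound 1 to compound 2 only shows that the size of such a change can be large. On this basis compound 3 is expected to land between the two measured numbers, with an expected step of a number 21 percentage points higher from compound 2 to compound 3 (beyond the scatter). For compound 3 the estimate is -35%, with a range from -65% to 0%.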

Compound 3, a percentage reported as activity, at one concentration (the size of the read-out at that concentration, not a potency): -59%
The estimate for compound 3 lay 24 percentage points above the measured number; the measured number falls inside the stated range.
By their numbers in this assay, from the lowest: compounds 3 and 2 (each within the scatter of the next); then compound 1.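

With 3-chlorophenyl in place of 2,4,6-trifluorophenyl on the amine nitrogen in the ring, this assay gives a number 3 percentage points lower from compound 2 to compound 3 (within the scatter), so these two aryl groups, one with a single chlorine and the other with three fluorines, cannot be told apart on this read-out. The large effect of leaving 4-methoxyphenyl is therefore not tied to the trifluorophenyl group alone: the change gives a number 44 percentage points lower from compound 1 to compound 3 (beyond the scatter), which matches the size of the earlier step, a number 41 percentage points lower from compound 1 to compound 2 (beyond the scatter). Among these three compounds, compound 1 stands apart, while compound 2 and compound 3 form one level. Going by these compounds, whether a phenyl ring carrying an amine or a carboxylic acid would join that level or fall with compound 1 remains open. Nothing given here accounts for the gap or for the match between the two aryl groups.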